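From but-3-en-1-yl to benzyl: compound 3 to compound 4

The source may hold more compounds than are shown below. What is called first, only, known or untested is meant among the compounds shown, and "the series" means these compounds.

Values in an ADME assay on RAW264.7 cells (Mus musculus) for cytotoxicity, read by MTT assay, with a stated time of 24 h, in the absence of a further agent (a lower number here means a stronger inhibitor, a higher number a weaker inhibitor), each one a limit:
- compound 1 `CCCCOc1ccc(C(O)C2OC(=O)c3c(OC)cc(OC)cc32)cc1` gives > 40000 nM
- compound 2 `COCCCOc1ccc(C(O)C2OC(=O)c3c(OC)cc(OC)cc32)cc1` gives > 40000 nM
- compound 3 `C=CCCOc1ccc(C(O)C2OC(=O)c3c(OC)cc(OC)cc32)cc1` gives > 40000 nM

Compound 3 stands at > 40000 nM as a limit, not a number. The set shows only the limit of > 40000 nM in this assay, at which 3 of the 3 values shown sit, and nothing finer. Compound 4 `COc1cc(OC)c2c(c1)C(C(O)c1ccc(OCc3ccccc3)cc1)OC2=O` follows with phenyl in place of allyl on a saturated chain carbon bound to an oxygen on an aromatic ring as its change: phenyl in place of allyl on a saturated chain carbon bound to an oxygen on an aromatic ring. Both a step that the two limits leave unreadable from compound 1 to compound 3 and a step that the two limits leave unreadable from compound 1 to compound 2 bear on it, and neither has a readable size. In this assay no step beyond the scatter is expected, in either direction, because a step that the two limits leave unreadable from compound 2 to compound 3 offers no size to carry over. The estimated move is a number no higher from compound 3 to compound 4 (the limit leaves the size open) on these grounds. Compound 4 is expected at 40000 nM with an estimated range of 20000 nM to 80000 nM in all.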

Compound 4, half-maximal inhibitory concentration: > 40000 nM
Compound 4 was reported as a limit; the forecaster's own chance of this, stated with the estimate: 80%; the middle value sits exactly at the limit.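

No step can be read among compound 1, compound 2, compound 3 and compound 4 in this assay, each value being a limit: the limit of > 40000 nM in this assay, at which 4 of the 4 values shown sit.

Still open, going by these compounds, is how far these four compounds lie from one another in this assay, and whether their chains differ there at all.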